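The compounds below may be only part of what the source reports. "The series", "measured", "known", "first", "only" and "open" are said of these compounds alone.

Compound 1, `CCCCCCCCCO[C@@H]1[C@@H](N)[C@@H](OCC(O)CNCCCO)O[C@H](CN)[C@H]1OCCCCCCCCC`, gives 13.7% in a toxicity assay on the whole organism (J774 cells) for cytotoxicity, with Mus musculus as the target, read by MTT assay, with a stated time of 24 h, tested at 30 uM; on this read-out lower numbers stand for a stronger effect and higher numbers for a weaker effect at the one concentration tested.
Compound 2, `CCCCCCCCCO[C@@H]1[C@@H](N)[C@@H](O[C@H]2[C@H](O)[C@@H](O)[C@H](N)C[C@@H]2N)O[C@H](CN)[C@H]1OCCCCCCCCC`, gives 48.6% in this assay.
Compound 3, `CCCCCCCCCO[C@@H]1[C@@H](N)[C@@H](OCC(O)CO)O[C@H](CN)[C@H]1OCCCCCCCCC`, gives 8.8% in this assay.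

Compound 3 carries the lowest of the three numbers, but compound 1 sits within the scatter of it, so the two cannot be told apart; only compound 2 stands clearly away, as the step of a number 39.8 percentage points lower from compound 2 to compound 3 (beyond the scatter) shows. Compound 4, `CCCCCCCCCO[C@@H]1[C@@H](N)[C@@H](OC[C@H](O)CN=[N+]=[N-])O[C@H](CN)[C@H]1OCCCCCCCCC`, differs from compound 3 at the end of the short side chain: 2-azido-1-hydroxyethyl in place of 1,2-dihydroxyethyl on a saturated chain carbon bound to an oxygen on a saturated carbon.

The step that bears most on this is a number 4.9 percentage points lower from compound 1 to compound 3 (within the scatter), where a different group was swapped at the end of the same chain and the number hardly moved. The large steps of a number 34.9 percentage points higher from compound 1 to compound 2 (beyond the scatter) and a number 39.8 percentage points lower from compound 2 to compound 3 (beyond the scatter) both involve replacing the whole chain by the diamino-dihydroxycyclohexyl ring, a far bigger change than the one at hand. A small step, not beyond the scatter, is therefore expected: a number 3.2 percentage points higher from compound 3 to compound 4 (within the scatter). Compound 4 is estimated at 12%, within a range from 3% to 25%.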

Compound 4, a percentage reported as activity, at one concentration (the size of the read-out at that concentration, not a potency): 5.9%
Compound 4: the middle estimate sits 6.1 percentage points above what was measured, and the stated range covers the measured number.
By their numbers in this assay, from the lowest: compounds 4, 3 and 1 (each within the scatter of the next); then compound 2.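

At the end of the short side chain, 2-azido-1-hydroxyethyl and 1,2-dihydroxyethyl cannot be told apart in this assay (a number 2.9 percentage points lower from compound 3 to compound 4 (within the scatter)), and the azide also stays within the scatter of the longer amino-bearing chain end (a number 7.8 percentage points lower from compound 1 to compound 4 (within the scatter)). Three different ends on this chain therefore give numbers that cannot be separated, while replacing the whole chain by the 4,6-diamino-2,3-dihydroxycyclohexyl ring still makes a large difference (a number 42.7 percentage points lower from compound 2 to compound 4 (beyond the scatter)). No measurement here explains why the chain end matters so little or why the ring matters so much.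

From the compounds shown here alone, it remains open whether a primary amine or a carboxylic acid at this chain end would stay with compounds 1, 3 and 4 or move toward compound 2. A longer chain in this position is equally untested by these compounds.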